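A Methyl Added to the Central Ring of Compound 2

A few compounds are considered here, and "the series" means these few. Any claim that something is new, unique, unknown or untested is made for them only; others in the source may bear on it.

Compound 2 `Nc1cccc2c(-c3cccc(NC(=O)c4cc(C(F)(F)F)cc(C(F)(F)F)c4)c3)ccnc12` is tested in a functional assay on A375P cells (Homo sapiens) for antiproliferative activity, read by MTT assay, with a stated time of 48 h (a higher number here means a weaker inhibitor, a lower number a stronger inhibitor), where compound 2 gives 3400 nM. Among the three measured compounds this number is the second highest: compound 1 `Nc1cccc2c(-c3cccc(NC(=O)c4cc(Cl)cc(C(F)(F)F)c4)c3)ccnc12` gives 18500 nM in this assay, and compound 3 `CC(=O)Nc1cccc2c(-c3cccc(NC(=O)c4cc(C(F)(F)F)cc(C(F)(F)F)c4)c3)ccnc12` gives 1000 nM. The two steps recorded so far are a 5.4-fold lower number from compound 1 to compound 2 (0.74 log units; beyond the scatter) and a 3.4-fold lower number from compound 2 to compound 3 (0.53 log units; beyond the scatter).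

Compound 4 `Cc1ccc(NC(=O)c2cc(C(F)(F)F)cc(C(F)(F)F)c2)cc1-c1ccnc2c(N)cccc12` differs from compound 2 in one place: methyl in place of hydrogen on an aromatic carbon. Neither measured step touches this position; the first concerns trifluoromethyl in place of chloro, the second acetyl in place of hydrogen on a ring nitrogen. Both were modest in size, but nothing measured tells how a methyl at this place acts, so no step beyond the scatter is expected in this assay, in either direction. Compound 4 is therefore expected to give 3400 nM, with a range from 1200 nM to 9500 nM. The expected step is no change at the digits printed from compound 2 to compound 4 (within the scatter).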

Compound 4, half-maximal inhibitory concentration: 7400 nM
Compound 4: the middle estimate sits 2.2-fold (0.34 log units) below what was measured; the range from low to high includes it.
By their numbers in this assay, from the lowest: compound 3; then compound 2; then compound 4; then compound 1.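

In this assay this position on the central ring of compound 2 is not silent: methyl in place of hydrogen, ortho to a 8-aminoquinolin-4-yl group and para to a large group, gives a 2.2-fold higher number from compound 2 to compound 4 (0.34 log units; beyond the scatter) and so moves toward a weaker inhibitor. The other single change made on compound 2, a 3.4-fold lower number from compound 2 to compound 3 (0.53 log units; beyond the scatter), lies elsewhere and runs the opposite way, so this is the first change shown to raise the number from compound 2. No measurement shown here accounts for the step.

What the compounds leave open is whether the number at this position would follow from an ethyl, a methoxy or an amine in place of the methyl. From the compounds shown here alone, it is also open whether the same methyl would move the number in the same direction on compound 3.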